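A few compounds are considered here, and "the series" means these few. Any claim that something is new, unique, unknown or untested is made for them only; others in the source may bear on it.

Measured compounds:
- compound 1, `CNC(=O)c1cccc(NC(=O)N2CCC(Oc3ccccc3C)CC2)c1`: 17 nM
- compound 2, `CNC(=O)c1cccc(NC(=O)N2CCC(Oc3ccccc3OC)CC2)c1`: 81 nM

In an assay on isolated protein for inhibition of acyl-CoA desaturase 1 (Mus musculus) (a lower number here means a stronger inhibitor, a higher number a weaker inhibitor), compound 2 gives the higher of the two numbers shown; its nearest neighbour is compound 1, and the step of a 4.8-fold higher number from compound 1 to compound 2 (0.68 log units; beyond the scatter) is beyond the scatter, so compound 2 stands as the weaker of the two measured inhibitors here.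

Compound 3, `CNC(=O)c1cccc(NC(=O)N2CCC(Oc3cc(F)ccc3Cl)CC2)c1`, has not yet been measured. It differs from compound 2 by 2-chloro-5-fluorophenyl in place of 2-methoxyphenyl on an oxygen on a saturated carbon, or, cut one bond further out, 2-methoxyphenoxy to 2-chloro-5-fluorophenoxy.

Among the compounds with values here, no measured step covers this change directly. Within the data shown here, the only step available, a 4.8-fold higher number from compound 1 to compound 2 (0.68 log units; beyond the scatter), shows that exchanging the group on this aromatic ring moves the number by a modest amount, and that the methoxy-bearing compound 2 is the weaker one. With the methoxy removed, the expectation for compound 3 is a number somewhere between compound 2 and compound 1, with wide uncertainty.

Estimated: for compound 3, 30 nM in this assay, range 8 nM to 110 nM, a step of a 2.7-fold lower number from compound 2 to compound 3 (0.43 log units; beyond the scatter).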

Compound 3, half-maximal inhibitory concentration: < 4 nM
Compound 3 ended at the assay's limit; the forecaster's own chance of this, stated with the estimate: 3%; middle value at least 7.5-fold (0.87 log units) from the limit.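

In this assay, compound 3 gives < 4 nM, which is a limit of the assay and not a number: the limit of < 4 nM in this assay, at which 1 of the 3 values shown sits.

Exchanging 2-methoxyphenyl for 2-chloro-5-fluorophenyl on an oxygen on a saturated carbon gives an at least 20-fold lower number from compound 2 to compound 3 (1.30 log units; beyond the scatter), and the matching exchange from the 2-methylphenyl group gives an at least 4.2-fold lower number from compound 1 to compound 3 (0.62 log units; beyond the scatter), so this place allows a much wider span of values than the earlier step alone, a 4.8-fold higher number from compound 1 to compound 2 (0.68 log units; beyond the scatter), had shown. The leaving and entering groups have the same count of heavy atoms, so within these compounds that count does not follow the change in the number.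

Within the data shown here, the contributions of the chlorine and the fluorine remain unseparated, since they enter together and no compound here carries a ring with only one of the two, and the limit leaves the full size of both steps unknown. Also open, on these data alone, is whether the result carries over to a pyridine ring at this place, or to a carboxylic acid in place of the methyl amide on the other side of the shared core.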